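Amide reversal at the top of the lipophilicity range

A few compounds are considered here, and "the series" means these few. Any claim that something is new, unique, unknown or untested is made for them only; others in the source may bear on it.

In a physicochemical assay for lipophilicity, at pH 7.4 (on this read-out lower numbers stand for lower lipophilicity and higher numbers for higher lipophilicity), compound 1 (`Cc1cc(C(=O)Nc2ccc(F)cc2)nn1Cc1cc(Cl)ccc1OCc1ccccc1`) gives 3. Compound 2 (`Cc1cc(C(=O)Nc2ccccn2)nn1Cc1cc(Cl)ccc1OCc1ccccc1`) returns only a limit, > 3.7. Compound 3 (`Cc1cc(C(=O)NCc2ccncc2)nn1Cc1cc(Cl)ccc1OCc1ccccc1`) also returns only a limit, > 3.7, so its position is bounded rather than known.

Compound 4 (`Cc1cc(NC(=O)C2CCOCC2)nn1Cc1cc(Cl)ccc1OCc1ccccc1`) carries one change from compound 3: ((oxan-4-yl)carbonyl)amino in place of ((pyridin-4-yl)methyl)carbamoyl on an aromatic carbon. The closest measured steps are on the amide-type nitrogen. Pyridin-2-yl in place of 4-fluorophenyl gave a number at least 0.70 log units higher from compound 1 to compound 2 (beyond the scatter), and (pyridin-4-yl)methyl in place of 4-fluorophenyl gave a number at least 0.70 log units higher from compound 1 to compound 3 (beyond the scatter). Between the two pyridine compounds there is a step that the two limits leave unreadable from compound 2 to compound 3. None of these steps replaces the whole group on the aromatic carbon, so they offer only weak guidance.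

In this assay the expected outcome, with no step beyond the scatter anticipated, is a step that the limit leaves unreadable from compound 3 to compound 4. Compound 4 may also land at the limit of > 3.7 in this assay, at which 2 of the 3 values shown sit. For compound 4 the expected value is 3.8, with an estimated range of 3.2 to 4.4.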

Compound 4, distribution coefficient: > 3.7
Compound 4: no number, only a limit; the forecaster's own chance of this, stated with the estimate: 55%; the middle value is on the limit's open side.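

In this assay compound 4 gives > 3.7, which is a limit and not a number. At this position on the aromatic carbon, ((oxan-4-yl)carbonyl)amino in place of (4-fluorophenyl)carbamoyl gives a number at least 0.70 log units higher from compound 1 to compound 4 (beyond the scatter), so a group with a non-aromatic ring and the amide turned round ends at the same limit as the two pyridine amides. The steps from compound 2 and compound 3 to compound 4 cannot be read, and compound 1 remains the only compound with a number: the limit of > 3.7 in this assay, at which 3 of the 4 values shown sit.

Any order among compound 2, compound 3 and compound 4 stays open. Also open, as far as these compounds go, is whether an amine or a carboxylic acid in place of ((oxan-4-yl)carbonyl)amino would give a number in this assay rather than a limit.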